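The source may hold more compounds than are shown below. What is called first, only, known or untested is meant among the compounds shown, and "the series" means these compounds.

Compound 1 `Cc1cccc(C[C@H]2COC(=O)[C@@H]2Cc2ccc(Cl)c(Cl)c2)c1`: 22000 nM
Compound 2 `O=C1OC[C@H](Cc2cccc(F)c2)[C@H]1Cc1ccc(Cl)c(Cl)c1`: 14000 nM

In a functional assay on HL-60 cells (Homo sapiens) for cytotoxicity, read by WST assay, with a stated time of 48 h (a lower number here means that less compound is needed, a higher number that more compound is needed for the effect), compound 2 gives 14000 nM, which lies within the scatter of compound 1 at 22000 nM. Compound 3 `O=C1OC[C@H](Cc2ccc(O)cc2)[C@H]1Cc1ccc(Cl)c(Cl)c1` has 4-hydroxyphenyl in place of 3-fluorophenyl on a saturated chain carbon bound to a saturated ring carbon. Within the data shown here, the only measured step that bears on this change is a 1.6-fold lower number from compound 1 to compound 2 (0.20 log units; within the scatter), and it swaps methyl for fluoro, so it is a weak guide. No hydroxyl change has been measured. No step beyond the scatter is therefore expected in this assay. The expected step is a 1.1-fold higher number from compound 2 to compound 3 (0.06 log units; within the scatter). For compound 3 the estimated value is 16000 nM, with an expected range of 6000 nM to 40000 nM.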

Compound 3, half-maximal effective concentration: 37000 nM
Estimate against measurement, compound 3: 2.3-fold (0.36 log units) below; low and high end bracket the measured number.
By their numbers in this assay, from the lowest: compounds 2, 1 and 3 (each within the scatter of the next, the first and the last beyond it).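

In this assay, among these compounds, the change to 4-hydroxyphenyl on a saturated chain carbon bound to a saturated ring carbon gives a 2.6-fold higher number from compound 2 to compound 3 (0.42 log units; beyond the scatter) and is the first step at this position to pass beyond the scatter. Measured against 3-methylphenyl, the same group gives a 1.7-fold higher number from compound 1 to compound 3 (0.23 log units; within the scatter) and stays within the scatter, so only the pairing with 3-fluorophenyl stands clear of it. Nothing available accounts for this step. The compounds shown leave open whether 3-hydroxyphenyl would read like 4-hydroxyphenyl here. They also leave open how a phenyl ring carrying an amine or a carboxylic acid would read at this place.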